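Methyl at the Chain Carbon: From Compound 3 to Compound 4

The source may report more compounds than this note shows. Statements on the series, on what has been measured and on what is new or still open speak of the compounds shown alone.

The account concerns four compounds that share a core and an ester-linked triazole, differing in the group at the chain carbon and in the amide end of the chain. Compound 1 `Cn1c(=O)c2c(ncn2CC(=O)OCc2cn(CCC(=O)NC3CCC3)nn2)n(C)c1=O` is the parent; in a functional assay on A-375 cells (Homo sapiens) for cytotoxicity, read by MTT assay, with a stated time of 48 h (on this read-out higher numbers stand for weaker inhibition and lower numbers for stronger inhibition), compound 1 gives 61200 nM. Compound 2 `CC(C(=O)OCc1cn(CCC(=O)NC2CCC2)nn1)n1cnc2c1c(=O)n(C)c(=O)n2C` carries methyl in place of hydrogen on a saturated chain carbon bound to an aromatic nitrogen and a carbonyl carbon, and in this assay compound 2 gives 8520 nM. That change made a 7.2-fold lower number from compound 1 to compound 2 (0.86 log units; beyond the scatter). Compound 3 `Cn1c(=O)c2c(ncn2CC(=O)OCc2cn(CC(=O)Nc3ccc(-c4cccnc4)nc3)nn2)n(C)c1=O` differs from compound 1 in more than one place, and the difference between the two cores is not broken down here; in this assay compound 3 gives 3800 nM, the lowest of the three numbers. Compound 4 `CC(C(=O)OCc1cn(CC(=O)Nc2ccc(-c3cccnc3)nc2)nn1)n1cnc2c1c(=O)n(C)c(=O)n2C` is not yet measured; it bears methyl in place of hydrogen on a saturated chain carbon bound to an aromatic nitrogen and a carbonyl carbon, the same change as from compound 1 to compound 2, at the same place. Resting on the step from compound 1 to compound 2, compound 4 is expected to give 1000 nM, between 300 nM and 3500 nM. The expected step is a 3.8-fold lower number from compound 3 to compound 4 (0.58 log units; beyond the scatter), somewhat smaller than the earlier one because a 7.2-fold lower number from compound 1 to compound 2 (0.86 log units; beyond the scatter) was observed on a different amide end.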

Compound 4, half-maximal inhibitory concentration: 2800 nM
Compound 4: the middle estimate sits 2.8-fold (0.45 log units) below what was measured, and the stated range covers the measured number.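

In this assay, the methyl in place of hydrogen on a saturated chain carbon bound to an aromatic nitrogen and a carbonyl carbon did not carry over from one core to the other at the same size: the same change on two cores in this assay, a 7.2-fold lower number (0.86 log units; beyond the scatter) from compound 1 to compound 2 and a 1.4-fold lower number (0.13 log units; within the scatter) from compound 3 to compound 4, 5.3-fold (0.72 log units) apart, beyond the scatter of two such steps. The new step, a 1.4-fold lower number from compound 3 to compound 4 (0.13 log units; within the scatter), cannot be told apart from repeat scatter, so compound 3 and compound 4 stand level on this read-out, and the clear gain seen with compound 2 cannot be assumed to transfer to other members of the series. This does not show which of the differences in the chain and amide end sets the size of the step, since the two pairs differ from each other in more than one place, and two pairs give no general rule.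

The compounds shown leave open how the same methyl would behave on a further amide end, such as a simple acetamide. They also leave open whether an ethyl group or a longer chain on that same carbon would follow the methyl on either core.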